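Shrinking the Ring at the End of the Chain

A few compounds are considered here, and "the series" means these few. Any claim that something is new, unique, unknown or untested is made for them only; others in the source may bear on it.

Compound 3 `COc1cc(/C=C/C(=O)Nc2ccccc2)ccc1OCCCCCCN1CCCCC1` gives 1.77 in a physicochemical assay for lipophilicity, using the shake flask method, measured as octanol-water partition, at pH 7.4; a higher number here means a more lipophilic compound, a lower number a more polar compound. Compound 2 `COc1cc(/C=C/C(=O)Nc2ccccc2)ccc1OCCCCCN1CCCCC1`, with 1.65, and compound 1 `COc1cc(/C=C/C(=O)Nc2ccccc2)ccc1OCCCN(C)C`, with 1.55, sit close by, since the step of a number 0.12 log units higher from compound 2 to compound 3 (within the scatter) and the step of a number 0.22 log units higher from compound 1 to compound 3 (within the scatter) are both small. Compound 4 `COc1cc(/C=C/C(=O)Nc2ccccc2)ccc1OCCCCCCN1CCCC1` is not yet measured; it differs from compound 3 in one place, (pyrrolidin-1-yl in place of piperidin-1-yl on a saturated chain carbon, six bonds along the chain from an oxygen on an aromatic ring). Within the data shown here, no measured step exchanges exactly these two rings, but every step so far that altered the amine end, namely a number 0.10 log units higher from compound 1 to compound 2 (within the scatter), a number 0.22 log units higher from compound 1 to compound 3 (within the scatter) and a number 0.12 log units higher from compound 2 to compound 3 (within the scatter), stayed within the scatter, and the present change is of a similarly modest kind. A small drop, or nothing beyond the scatter, is therefore expected in this assay, a step of a number 0.17 log units lower from compound 3 to compound 4 (within the scatter). Compound 4 is estimated at 1.6, most likely between 1.35 and 1.85.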

Compound 4, partition coefficient: 1.76
Beside the measured number, compound 4's estimate is 0.16 log units below it, within the range that was stated.
By their numbers in this assay, from the lowest: compounds 1, 2, 4 and 3 (each within the scatter of the next).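

Exchanging piperidin-1-yl for pyrrolidin-1-yl, on a saturated chain carbon six bonds along the chain from an oxygen on an aromatic ring, gives in this assay a first direct view of this ring change (a number 0.01 log units lower from compound 3 to compound 4 (within the scatter)). Compound 4 also stays close to the two compounds with other amine ends (a number 0.11 log units higher from compound 2 to compound 4 (within the scatter); a number 0.21 log units higher from compound 1 to compound 4 (within the scatter)). No evidence is available to explain these small steps. As far as these compounds go, what remains open is how this assay would respond at this place to morpholin-4-yl, whose ring holds oxygen as well as nitrogen, or to a primary amine.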